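The source may report more compounds than this note shows. Statements on the series, on what has been measured and on what is new or still open speak of the compounds shown alone.

Working notes on the series. Of the compounds shown here, three that share one core have been measured in an assay on isolated protein for displacement of a labelled ligand from Alpha-1A adrenergic receptor (Bos taurus); a lower number here means a stronger inhibitor, a higher number a weaker inhibitor. Compound 1, `COc1ccccc1N1CCN(CCCNc2ncccc2C(=O)NC(C)(C)C)CC1`, gives 1.59 nM in this assay. Compound 2, `COc1ccccc1N1CCN(CCCNc2nc(C)cc(C)c2C(N)=O)CC1`, gives 1.59 nM. Compound 3, `COc1ccccc1N1CCN(CCCNc2ccncc2C(=O)N(C)C)CC1`, gives 0.794 nM; the two other numbers lie within the usual scatter of it, so the three compounds are not separated by this assay on the data in hand. Among the measured compounds shown here, no pair of them differs in only one place, so no single step is available to read off.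

Compound 4, `COc1ccccc1N1CCN(CCCNc2ccncc2C(=O)N(C(C)C)C(C)C)CC1`, has not yet been measured in this assay. It differs from compound 3 in one place: diisopropylamino in place of dimethylamino on a carbonyl carbon. The measured compounds differ from one another in the group on the carbonyl carbon, and among them compound 1 gives 1.59 nM, which is the only hint in the set about how far this place tolerates other groups. No step beyond the scatter is therefore expected; the estimated step of a 1.6-fold higher number from compound 3 to compound 4 (0.21 log units; within the scatter) is small. Compound 4 is expected to give about 1.3 nM in this assay, with a range from 0.4 nM to 4 nM.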

Compound 4, inhibition constant: 1.59 nM
Estimate against measurement, compound 4: 1.2-fold (0.09 log units) below, within the range that was stated.
By their numbers in this assay, from the lowest: compounds 3, 1, 2 and 4 (each within the scatter of the next).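

In this assay, diisopropylamino in place of dimethylamino on a carbonyl carbon gives a 2.0-fold higher number from compound 3 to compound 4 (0.30 log units; within the scatter), so a group of 7 heavy atoms stands where one of 3 stood with no step beyond the scatter. Among the compounds shown here, this is the only step that reads a change at one place, since the earlier compounds differed from one another in more than one place. Nothing measured here bears on why the step has this size.

Both groups compared are dialkylamino groups without a ring or a hydrogen-bond donor, so a single step says nothing about how an unsubstituted amino group on the carbonyl carbon would read on this core. On these data alone, a carboxylic acid in place of the amide also remains open, as does any longer chain on the amide nitrogen.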